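Taking the fluoro group off compound 2

The compounds below may be only part of what the source reports. "The series", "measured", "known", "first", "only" and "open" are said of these compounds alone.

Compound 1 `CC(C)OC[C@H](Oc1ncnc2c1cnn2-c1ncccc1Cl)C(=O)Nc1ccc(C#N)cn1` and compound 2 `CC(C)OC[C@H](Oc1ncnc2c1cnn2-c1ncccc1Cl)C(=O)Nc1ccc(F)cn1` share the same core and differ in one group only. In a physicochemical assay for lipophilicity (a lower number here means a more polar compound, a higher number a more lipophilic compound), compound 1 gives 2.5 and compound 2 gives 2.7. These two numbers are within the scatter of each other, so compound 2 cannot yet be told apart from compound 1 on this scale.

The next compound is compound 3 `CC(C)OC[C@H](Oc1ncnc2c1cnn2-c1ncccc1Cl)C(=O)Nc1ccccn1`, which has hydrogen in place of fluoro on an aromatic carbon. For the measured compounds named here, the only measured step that bears on this change is a number 0.20 log units higher from compound 1 to compound 2 (within the scatter), where fluoro replaces cyano at the same place. That is a different swap, so it is a guide to size and not a direct reading. Going by the values given here, no measurement yet shows what hydrogen does at this place. A small step towards a lower number is therefore expected, one that stays inside the scatter. In this assay the expected change is a number 0.20 log units lower from compound 2 to compound 3 (within the scatter). For compound 3 the estimated value is 2.5, with an expected range from 2.2 to 2.8.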

Compound 3, distribution coefficient: 2.5
For compound 3 middle estimate and measured number coincide at the digits printed; the measured number falls inside the stated range.
By their numbers in this assay, from the lowest: compounds 1, 3 and 2 (each within the scatter of the next).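

Hydrogen gives this position a bare reference point, and in this assay the swap from fluoro to hydrogen reads as follows (a number 0.20 log units lower from compound 2 to compound 3 (within the scatter)), while the swap from cyano to hydrogen reads as follows (no change at the digits printed from compound 1 to compound 3 (within the scatter)). The earlier pair compared only two substituents, whereas these steps show that neither fluoro nor cyano can be told apart from plain hydrogen on this scale at this aromatic carbon, two atoms from the ring nitrogen. No independent measurement is available that would account for this result.

The compounds shown leave open whether a group of a different kind on this aromatic carbon, such as an amine, a carboxylic acid or a longer chain, would give a number beyond the scatter of these three. They also leave open whether fluoro, cyano and hydrogen would stay this close together on a core other than the shared one, or in a measurement of anything other than this assay.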